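The source may hold more compounds than are shown below. What is called first, only, known or untested is meant among the compounds shown, and "the series" means these compounds.

In an assay on cells with melanin-concentrating hormone receptor 1 (Homo sapiens) as the target, read by radioligand binding (on this read-out higher numbers stand for weaker inhibition and lower numbers for stronger inhibition), compound 1 `CC1CCCCC1Oc1cccc2ccc(N)nc12` gives 32 nM. Compound 2 `CC1CCC(Oc2cccc3ccc(N)nc23)C1` gives 823 nM. Compound 3 `Nc1ccc2cccc(OCC3CCCO3)c2n1` reaches only the limit of the assay, > 2000 nM, so no exact number is known for it, and it stands at the weak end of the three compounds measured. The step of an at least 2.4-fold higher number from compound 2 to compound 3 (0.38 log units; beyond the scatter) shows that putting (oxolan-2-yl)methyl in place of 3-methylcyclopentyl cost at least that much binding, and because the value sits at the limit of > 2000 nM in this assay, at which 1 of the 3 values shown sits, the true loss may be larger. Compound 4 `CCCOc1cccc2ccc(N)nc12` differs from compound 3 by ethyl in place of oxolan-2-yl on a saturated chain carbon bound to an oxygen on an aromatic ring. Read one bond further out, this is propyl in place of (oxolan-2-yl)methyl: the five-membered ring with its oxygen is gone and a short open chain remains. Within the data shown here, no measured step covers this exact exchange; the only measured step touching this position moved toward weaker binding when the oxolane ring entered, so taking it away again might recover some binding, yet nothing measured here shows what a plain propyl chain does at this position. The step that the limit leaves unreadable from compound 3 to compound 4 is therefore expected to be small. Compound 4 is estimated at 3000 nM, between 700 nM and 12000 nM, with a fair chance that only a limit is again reported.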

Compound 4, half-maximal inhibitory concentration: 1100 nM
Estimate against measurement, compound 4: 2.7-fold (0.44 log units) above; measured number inside the range.
By their numbers in this assay, from the lowest: compound 1; then compounds 2 and 4 (each within the scatter of the next). At a limit, above all of these: compound 3.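

Propyl in place of (oxolan-2-yl)methyl gives an at least 1.8-fold lower number from compound 3 to compound 4 (0.25 log units; that floor lies within the scatter), and this can be read only as a floor, because compound 3 stands at a limit: the limit of > 2000 nM in this assay, at which 1 of the 4 values shown sits.

The firmer comparison at this position is a 1.3-fold higher number from compound 2 to compound 4 (0.13 log units; within the scatter), which comes from propyl in place of 3-methylcyclopentyl on an oxygen on an aromatic ring. In this assay, this open chain and this ring therefore cannot be told apart, so the ring of compound 2 is not needed to keep binding in this range.

In the same assay, compound 1 gives 32 nM, and the compounds shown leave open whether a longer chain such as butyl, or a branched one such as isopropyl, would bring the number closer to that value. They also leave open what an amine at the end of the propyl chain would do to binding at this position.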